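The source may hold more compounds than are shown below. What is called first, only, known or untested is meant among the compounds shown, and "the series" means these compounds.

Compound 1 `CC(C)[C@H](NC(=O)COc1cccc2ccccc12)C(=O)N[C@@H](CC(=O)O)C(=O)COC(=O)c1c(Cl)cccc1Cl`: 10600 nM
Compound 2 `CC(C)[C@H](NC(=O)COc1cccc2ccccc12)C(=O)N[C@@H](CC(=O)O)C(=O)COc1ccc(F)cc1`: > 100000 nM

Among the compounds with values here, compound 1 supplies the only plain number in a functional assay on Jurkat cells (Homo sapiens) (on this read-out lower numbers stand for stronger inhibition and higher numbers for weaker inhibition), where compound 1 gives 10600 nM. For compound 2 the read-out in this assay is a limit, > 100000 nM, and not a number. Compound 3 `CC(C)[C@H](NC(=O)COc1cccc2ccccc12)C(=O)N[C@@H](CC(=O)O)C(=O)COc1cc(F)cc(F)c1` has not yet been measured in this assay. It differs from compound 1 in one place: 3,5-difluorophenyl in place of (2,6-dichlorophenyl)carbonyl on an oxygen on a saturated carbon. Within the data shown here, one measured step bears on this change, an at least 9.4-fold higher number from compound 1 to compound 2 (0.97 log units; beyond the scatter), which put a 4-fluorophenyl at the same place and moved the number beyond the scatter, ending at the limit of > 100000 nM in this assay, at which 1 of the 2 values shown sits. Because compound 3 carries a 3,5-difluorophenyl at that place, a weakening of similar size is expected, a 9.4-fold higher number from compound 1 to compound 3 (0.97 log units; beyond the scatter), with a fair chance that this assay again reports only a limit. The estimate for compound 3 is 100000 nM, ranging from 30000 nM to 300000 nM.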

Compound 3, half-maximal inhibitory concentration: > 100000 nM
Compound 3 gave a limit, no number; the forecaster's own chance of this, stated with the estimate: 60%; the middle value sits exactly at the limit.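

In this assay, placing a 3,5-difluorophenyl on this oxygen gives an at least 9.4-fold higher number from compound 1 to compound 3 (0.97 log units; beyond the scatter). The loss seen with the 4-fluorophenyl of compound 2 therefore also appears with a second fluorinated phenyl, so at this position it does not depend on a single fluorine pattern. Compound 2 and compound 3 both give a limit rather than a number, so the step between them cannot be read and any difference between the two fluorine patterns stays hidden: the limit of > 100000 nM in this assay, at which 2 of the 3 values shown sit.

Still open, going by these compounds, is which part of the (2,6-dichlorophenyl)carbonyl group of compound 1 goes with its measurable number. A 2,6-dichlorophenoxy group, which keeps the chlorines without the carbonyl, and a plain phenylcarbonyl group, which keeps the carbonyl without the chlorines, would help separate the two.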